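This account rests on a few compounds, and the source may have more. Where it says the series, first, only, none or still open, it means among the compounds named here.

Measured compounds in an assay on HEK-293T cells for antagonist activity at vitamin D3 receptor (Homo sapiens), read by a luciferase reporter, with a stated time of 24 h; a higher number here means a weaker inhibitor, a lower number a stronger inhibitor:
- Compound 1 `CCC(CC)n1c(-c2ccc(OCc3c(-c4c(Cl)cccc4Cl)noc3C(C)C)cc2F)nc2ccc(C(=O)O)cc21`; in this assay compound 1 gives > 10000 nM, which is a limit of the assay and not a number.
- Compound 2 `CC(C)c1onc(-c2c(Cl)cccc2Cl)c1COc1ccc(-c2nc3ccc(C(=O)O)cc3n2C2CC2)cc1`; in this assay compound 2 gives 3200 nM.
- Compound 3 `CC(C)c1onc(-c2c(Cl)cccc2Cl)c1COc1ccc(-c2nc3ccc(C(=O)O)cc3n2C)c(Cl)c1`; in this assay compound 3 gives 3520 nM.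

Compound 2 holds the lowest of the two numbers recorded; its nearest neighbour is compound 3, and the gap between the two lies within the scatter, so no order can be read between them. One of the three values sits at the limit of > 10000 nM in this assay, at which 1 of the 3 values shown sits, and that value belongs to compound 1. No pair of these compounds differs in a single place, so no measured step is available in this series.

The next compound, compound 4 `CC(C)c1onc(-c2c(Cl)cccc2Cl)c1COc1ccc(-c2nc3ccc(C(=O)O)cc3n2C2CCCCC2)cc1`, is reached from compound 2 by one change: cyclohexyl in place of cyclopropyl on an aromatic nitrogen.

Among the compounds with values here, with no measured step to lean on, the expectation for this change is a small shift, if any, toward a higher number, and it may well stay within the scatter. Compound 4 is therefore expected to give about 4500 nM in this assay, with a plausible range from 1500 nM to 12000 nM. That estimate means a step of a 1.4-fold higher number from compound 2 to compound 4 (0.15 log units; within the scatter), which is expected to be modest.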

Compound 4, half-maximal inhibitory concentration: 1450 nM
Compound 4: middle estimate off by 3.1-fold (0.49 log units), on the high side; measured number below the stated range.
By their numbers in this assay, from the lowest: compound 4; then compounds 2 and 3 (each within the scatter of the next). At a limit, above all of these: compound 1.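

In this assay the group on the aromatic nitrogen now has its first measured single-place step, for cyclohexyl in place of cyclopropyl (a 2.2-fold lower number from compound 2 to compound 4 (0.34 log units; beyond the scatter)). The step is modest but beyond the scatter, and it shows that this position can carry the larger ring, with 6 heavy atoms against 3, without a rise in the number. Nothing measured here accounts for the step, so it remains an observation on one pair of compounds.

From the compounds shown here alone, it remains open whether a cyclobutyl or cyclopentyl group on the same nitrogen would follow the direction of this one pair, and whether an amine or a hydroxyl on the cyclohexyl ring would keep the lower number. Compound 1 gives > 10000 nM in this assay, which is a limit of the assay, and as it differs from compound 4 in more than one place, it cannot be read as a step at this position.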